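The source may hold more compounds than are shown below. What is called first, only, known or untested is meant among the compounds shown, and "the series" means these compounds.

Measured so far:
Compound 1, `CC(C)(C)N1C[C@@H](C(=O)Nc2nccn2Cc2cccc(Cl)c2)[C@H](c2ccc(F)cc2F)C1` — in a functional assay for agonist activity at Melanocyte-stimulating hormone receptor (Homo sapiens), read by cAMP accumulation (a lower number here means that less compound is needed, a higher number that more compound is needed for the effect), compound 1 gives 1270 nM.
Compound 2, `CC(C)(C)N1C[C@@H](C(=O)Nc2nccn2Cc2ccc(Cl)cc2)[C@H](c2ccc(F)cc2F)C1` — in this assay compound 2 gives > 10000 nM, which is a limit of the assay and not a number.

Compound 2 therefore stands at the weak end of what this assay can report, with no exact figure. For the measured compounds named here, the only measured step, an at least 7.8-fold higher number from compound 1 to compound 2 (0.89 log units; beyond the scatter), shows that moving the chlorine on the phenyl ring already costs a good deal, and the limit of > 10000 nM in this assay, at which 1 of the 2 values shown sits, marks that compound 2 sits at the limit.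

Compound 3 is `CC(C)(C)N1C[C@@H](C(=O)Nc2nccn2Cc2ccccc2-c2ccccc2)[C@H](c2ccc(F)cc2F)C1`. Its change from compound 2 is 2-phenylphenyl in place of 4-chlorophenyl on a saturated chain carbon bound to an aromatic nitrogen. Going by the values given here, no measured step touches a 2-phenylphenyl group, so the step from compound 1 to compound 2 bears only indirectly: it shows that this part of the molecule is sensitive, but not which way a second ring will push. With compound 2 at the limit, a further loss cannot be read, while a gain is possible but unsupported. The expected step of an at least 1.6-fold lower number from compound 2 to compound 3 (0.22 log units; that floor lies within the scatter) is therefore uncertain, and compound 3 is estimated at 6000 nM, within 800 nM to 40000 nM.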

Compound 3, half-maximal effective concentration: 527 nM
Compound 3: middle estimate off by 11-fold (1.06 log units), on the high side; the whole stated range lies above it.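

The earlier compounds shown here showed only that this place on a saturated chain carbon bound to an aromatic nitrogen can lose activity. Compound 3 shows that it can also gain: putting 2-phenylphenyl, with 2 six-membered aromatic rings, in place of 4-chlorophenyl brings an at least 18-fold lower number from compound 2 to compound 3 (1.27 log units; beyond the scatter). That step is only a floor, because compound 2 stands at a limit of the assay and not at a number: the limit of > 10000 nM in this assay, at which 1 of the 3 values shown sits. The firmer comparison has a measured value at both ends, a 2.4-fold lower number from compound 1 to compound 3 (0.38 log units; beyond the scatter), and it places compound 3 ahead of both chlorine-bearing compounds in this assay, so a larger group with a second ring is accepted here.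

The change in compound 3 alters both what is attached to the ring and where it is attached, and the compounds shown cannot separate these two effects. From the compounds shown here alone, a 2-chlorophenyl group would test the attachment point alone, while a 3-phenylphenyl or 4-phenylphenyl group would show whether the second ring works only as 2-phenylphenyl, and the same question stays open for a 2-benzylphenyl group with its longer link.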